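A few compounds are considered here, and "the series" means these few. Any claim that something is new, unique, unknown or untested is made for them only; others in the source may bear on it.

Measured compounds:
- compound 1 `COc1ccc(OCC(=O)N2CCN(c3ccc(C(F)(F)F)cc3[C@@H](N)CC(C)C)CC2)cc1`: 3800 nM
- compound 2 `CC(C)C[C@H](N)c1cc(C(F)(F)F)ccc1N1CCN(C(=O)C(C)Cc2ccc(Cl)cc2O)CC1`: 36 nM
- compound 3 `CC(C)C[C@H](N)c1cc(C(F)(F)F)ccc1N1CCN(C(=O)CSc2ccc(Cl)cc2Cl)CC1`: 1500 nM

In an assay on HEK293 cells for displacement of a labelled ligand from Melanocortin receptor 4 (Homo sapiens) (on this read-out lower numbers stand for stronger inhibition and higher numbers for weaker inhibition), compound 1 gives the highest number of the three; its nearest neighbour is compound 3, and compound 2 stands furthest from it. Compound 4 `Cc1cc(CC(C)C(=O)N2CCN(c3ccc(C(F)(F)F)cc3[C@@H](N)CC(C)C)CC2)ccc1Cl` differs from compound 1 in one place: 1-(4-chloro-3-methylbenzyl)ethyl in place of (4-methoxyphenoxy)methyl on a carbonyl carbon. The step that bears most directly on it is a 110-fold lower number from compound 1 to compound 2 (2.02 log units; beyond the scatter), which also places a 1-substituted ethyl bearing a chlorinated benzyl group on the carbonyl carbon; the smaller step of a 2.5-fold lower number from compound 1 to compound 3 (0.40 log units; beyond the scatter) points the same way. A large downward step is therefore expected for compound 4, a 25-fold lower number from compound 1 to compound 4 (1.40 log units; beyond the scatter), though perhaps not the full extent seen for compound 2. The estimated value for compound 4 is 150 nM, with a range from 40 nM to 600 nM.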

Compound 4, inhibition constant: 71 nM
Estimate against measurement, compound 4: 2.1-fold (0.32 log units) above; the measured number falls inside the stated range.
By their numbers in this assay, from the lowest: compounds 2 and 4 (each within the scatter of the next); then compound 3; then compound 1.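

In this assay, the step of a 54-fold lower number from compound 1 to compound 4 (1.73 log units; beyond the scatter) and the step of a 21-fold lower number from compound 3 to compound 4 (1.32 log units; beyond the scatter) show that the low number at this carbonyl carbon does not rest on the 4-chloro-2-hydroxyphenyl group of compound 2. With a 2.0-fold higher number from compound 2 to compound 4 (0.29 log units; within the scatter), the 4-chloro-3-methylphenyl and 4-chloro-2-hydroxyphenyl groups cannot be told apart on this read-out, and 1-(4-chloro-3-methylbenzyl)ethyl counts no hydrogen-bond donors. Nothing measured here explains these steps.

The compounds shown change the chain's branching and its oxygen or sulfur together, so which of these carries the steps stays open. On these data alone, how a carboxylic acid or an amine in place of the chlorine would read also stays open.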